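A few compounds are considered here, and "the series" means these few. Any claim that something is new, unique, unknown or untested is made for them only; others in the source may bear on it.

Measured so far in one cell-based test:
compound 1, `C=C(Br)C(=O)Nc1ccc(/C=C2\SC(=O)N(CC)C2=O)cc1`, gives 2300 nM;
compound 2, `CCN1C(=O)S/C(=C\c2ccc(N)cc2)C1=O`, gives 76000 nM;
compound 3, `C=C(Br)C(=O)Nc1ccc(/C=C2\SC(=O)N(Cc3ccc(C(C)(C)C)cc3)C2=O)cc1`, gives 4000 nM.

All three numbers come from a functional assay on FM3A cells (Mus musculus) for cytotoxicity, read by cell counting, with a stated time of 2 days; on this read-out lower numbers stand for stronger inhibition and higher numbers for weaker inhibition. Compound 1 and compound 2 differ in one place: hydrogen in place of (1-bromoethenyl)carbonyl on a nitrogen on an aromatic ring. That change gave a 33-fold higher number from compound 1 to compound 2 (1.52 log units; beyond the scatter), so removing this group cost most of the activity. Compound 3 keeps the group of compound 1 but sits on a different core; the difference between the two cores is 4-(tert-butyl)phenyl in place of methyl on a saturated chain carbon bound to an amide-type nitrogen in a ring, and that change gave a 1.7-fold higher number from compound 1 to compound 3 (0.24 log units; within the scatter), which is not a real difference.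

Compound 4, `CC(C)(C)c1ccc(CN2C(=O)S/C(=C\c3ccc(N)cc3)C2=O)cc1`, has not yet been measured in this assay. It stands to compound 3 as compound 2 stands to compound 1: the difference is hydrogen in place of (1-bromoethenyl)carbonyl on a nitrogen on an aromatic ring, at a place described in the same words, so it is the same change seen once already. Because a 33-fold higher number from compound 1 to compound 2 (1.52 log units; beyond the scatter) was seen for this change on the other core, a step of similar size is expected here, a 30-fold higher number from compound 3 to compound 4 (1.48 log units; beyond the scatter). Compound 4 is therefore expected to give about 120000 nM, most likely between 40000 nM and 400000 nM.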

Compound 4, half-maximal inhibitory concentration: 80000 nM
Beside the measured number, compound 4's estimate is 1.5-fold (0.18 log units) above it; the range from low to high includes it.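

In this assay, replacing the (1-bromoethenyl)carbonyl group with hydrogen gave a 20-fold higher number from compound 3 to compound 4 (1.30 log units; beyond the scatter) and so repeated on the core of compound 3 the large loss seen on the core of compound 1. The two steps agree within the scatter, so in this pair of cores the change carried over with much the same size: the same change on two cores in this assay, a 33-fold higher number (1.52 log units; beyond the scatter) from compound 1 to compound 2 and a 20-fold higher number (1.30 log units; beyond the scatter) from compound 3 to compound 4, 1.7-fold (0.22 log units) apart, within the scatter of two such steps. Among these compounds, this rests on only two pairs in a single cell test, so it does not show that the step would hold on any further core, and a count of cells does not say what the compounds act on.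

The compounds shown leave open which part of the (1-bromoethenyl)carbonyl group matters, a question that a plain acetyl group, which has no bromine and no double bond between carbons, could address. They also leave open whether the step stays the same with a carboxylic acid or a longer chain on the amide-type nitrogen in the ring.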